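A few compounds are considered here, and "the series" means these few. Any claim that something is new, unique, unknown or untested is made for them only; others in the source may bear on it.

In a functional assay on the whole organism (Pleural cavity) for inhibition, with Rattus norvegicus as the target, at a dose of 25 mg/kg (a higher number here means more inhibition at the dose given (going by the name of the read-out), a lower number less inhibition), compound 1 `CC1(Cc2ccccc2)C(=O)N(c2ccccc2)c2ncccc21` gives 0%, and compound 2 `CC1(C)C(=O)N(Cc2ccccc2)c2ncccc21` gives 12%. Of the two numbers, compound 2 stands highest, a gap to compound 1 that lies beyond the scatter. Compound 3 `CC1(C)C(=O)N(Cc2ccc(Cl)cc2)c2ncccc21` differs from compound 2 in one place: chloro in place of hydrogen on an aromatic carbon. Within the data shown here, no measured pair shows what this change does, so the expected step from compound 2 to compound 3 is small, a number 6 percentage points higher from compound 2 to compound 3 (within the scatter), upward but within the scatter. Compound 3 is therefore expected to give 18% in this assay, with a range from 0% to 40%.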

Compound 3, a percentage reported as inhibition, in the whole organism at one dose (the size of the read-out at that dose, not a potency): 0%
Compound 3: middle estimate off by 18 percentage points, on the high side, within the range that was stated.
By their numbers in this assay, from the lowest: compounds 1 and 3 (each within the scatter of the next); then compound 2.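

In this assay, among these compounds, chloro in place of hydrogen on an aromatic carbon, para to a large group, gives the first step that can be read: a number 12 percentage points lower from compound 2 to compound 3 (beyond the scatter). The position is therefore not indifferent to substitution, since this one added chlorine atom removes the modest inhibition of compound 2, and compound 3 gives 0%. Nothing available explains this loss. The compounds shown leave open whether the loss is specific to chloro. A fluoro or methoxy group at the same place could show whether other groups behave alike.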